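The compounds below may be only part of what the source reports. "The series", "measured", "known", "first", "only" and "open" are said of these compounds alone.

Working notes on the series. All three measured compounds share the same core bearing two benzyl ether groups, joined through a short linker to a five-membered aromatic ring with 3 nitrogen. Compound 1 `O=C1O/C(=C\Cn2cc(-c3ccc(Br)cc3)nn2)C(OCc2ccccc2)=C1OCc1ccccc1` gives 24300 nM in a functional assay on HeLa cells (Homo sapiens) for antiproliferative activity, read by MTT assay, with a stated time of 72 h; on this read-out lower numbers stand for stronger inhibition and higher numbers for weaker inhibition. For the measured compounds named here, compound 2 `Cc1ccc(-c2cn(C/C=C3\OC(=O)C(OCc4ccccc4)=C3OCc3ccccc3)nn2)cc1` gives 7480 nM in this assay; the only single-point step measured so far is a 3.2-fold lower number from compound 1 to compound 2 (0.51 log units; beyond the scatter). Compound 3 `CCCCc1cn(C[C@H](O)[C@H]2OC(=O)C(OCc3ccccc3)=C2OCc2ccccc2)nn1`, which carries a butyl group on the five-membered ring and a hydroxyl in the linker, gives 18100 nM in this assay. Among the three numbers compound 3 stands second highest: it lies close to compound 1, within the scatter, while compound 2 shows a lower number than compound 3, beyond the scatter.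

Compound 4 `C[Si](C)(C)c1cn(C[C@H](O)[C@H]2OC(=O)C(OCc3ccccc3)=C2OCc2ccccc2)nn1` has not been measured. Relative to compound 3 it carries a group of 4 heavy atoms (3 carbon, 1 silicon; no ring) in place of a group of 4 heavy atoms (4 carbon; no ring), on an aromatic carbon. Going by the values given here, the one measured step, a 3.2-fold lower number from compound 1 to compound 2 (0.51 log units; beyond the scatter), concerns a different place on a different ring and a different pair of groups, so it does not cover this change; no measured step bears directly on it. With nothing to argue for a shift, the expectation is a step within the scatter, a 1.0-fold lower number from compound 3 to compound 4 (0.00 log units; within the scatter). Compound 4 is therefore estimated at 18000 nM, with a range from 7000 nM to 45000 nM.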

Compound 4, half-maximal inhibitory concentration: 22300 nM
Estimate against measurement, compound 4: 1.2-fold (0.09 log units) below; the measured number falls inside the stated range.
By their numbers in this assay, from the lowest: compound 2; then compounds 3, 4 and 1 (each within the scatter of the next).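

For the compounds shown here, at this aromatic carbon of the five-membered aromatic ring with 3 nitrogen, with the hydroxyl linker held constant, a 1.2-fold higher number from compound 3 to compound 4 (0.09 log units; within the scatter) gives the first measured step at this position in this assay. Butyl and the group of 4 heavy atoms containing silicon are not told apart on this read-out, so this exchange of two unbranched-versus-silicon-centred groups of equal heavy-atom count produces no shift beyond the scatter in this pair. No measurement at hand explains the result.

The compounds shown leave open how this carbon responds to groups of a different kind or size, such as a primary amine, a carboxylic acid, a longer chain such as octyl, or a phenyl ring on the same hydroxyl linker. They also leave open whether the same exchange of butyl for the silicon-containing group would behave alike on the unsaturated linker of compound 1 and compound 2, where this ring carbon bears an aryl group instead.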